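The source may hold more compounds than are shown below. What is called first, only, known or untested is meant among the compounds shown, and "the series" means these compounds.

In a functional assay on HT-29 cells (Homo sapiens) for cytotoxicity (on this read-out lower numbers stand for stronger inhibition and higher numbers for weaker inhibition), two compounds have been tested so far. Compound 1 `COc1cc(/C=C\c2ccnc3ccccc23)cc(OC)c1OC` gives 15800 nM, which is a weak reading on this scale.

Compound 2 `COc1cc(/C=C\c2ccc3nc(C)c(C)nc3c2)cc(OC)c1OC` gives > 15800 nM. This is a limit of the assay and not a number, so compound 2 has no exact position on the scale.

The next compound, compound 3 `COc1cc(/C=C/c2ccc3nc(C)c(C)nc3c2)cc(OC)c1OC`, is built from the same pieces as compound 2. The change is the two compounds have the same atoms and bonds and differ only in configuration as drawn: 1 of 1 stereo elements differ; a double bond is drawn Z in compound 2 and E in compound 3. Nothing is added or removed, so the only difference is how the two halves of the molecule are arranged around that double bond.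

For the measured compounds named here, no pair of measured compounds shows what such a switch does in this assay, so there is no measured step to borrow. Going by the values given here, the only exact number available is the weak reading of compound 1 at 15800 nM, and it gives no sign of strong inhibition in this set. The estimated step that the limit leaves unreadable from compound 2 to compound 3 is therefore expected to stay within the usual scatter, with no clear direction.

For compound 3, the expected value is 16000 nM, with an estimated range from 6000 nM to 40000 nM.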

Compound 3, half-maximal inhibitory concentration: > 15800 nM
Compound 3: a limit, no number; the forecaster's own chance of this, stated with the estimate: 65%; the middle value lies beyond the limit too.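

Compound 3 gives > 15800 nM, which is a limit of the assay and not a number. Compound 2 also sits at a limit, so no step can be read between compound 2 and compound 3. The compounds shown leave open whether a double bond drawn Z or drawn E changes the reading in this assay at all.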